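The source may hold more compounds than are shown below. What is called first, only, known or untested is meant among the compounds shown, and "the series" means these compounds.

Series notes. Compound 1 `COc1cc(/C=C/C(=O)c2cccc(-n3cc(-c4ccc(Cl)cc4)[nH]c3=O)c2)cc(OC)c1OC` in a functional assay on Malme-3M cells (Homo sapiens) for inhibition (a higher number here means a weaker inhibitor of growth, a lower number a stronger inhibitor of growth), gives 18100 nM. Compound 2 `COc1cc(/C=C/C(=O)c2cccc(-n3cc(-c4ccccc4)[nH]c3=O)c2)ccc1O` gives 2670 nM in this assay, and compound 3 `O=C(/C=C/c1cccc(O)c1)c1cccc(-n2cc(-c3ccccc3)[nH]c2=O)c1` gives 6210 nM. Compound 3 thus holds the second highest of the three numbers: the change from compound 2 to compound 3 brought a 2.3-fold higher number from compound 2 to compound 3 (0.37 log units; beyond the scatter), and compound 1 sits a further step higher still.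

Compound 4 `O=C(/C=C/c1cccc(O)c1)c1cccc(-n2cc(-c3ccc(Cl)cc3)[nH]c2=O)c1` differs from compound 3 by chloro in place of hydrogen on an aromatic carbon; read one bond further out, phenyl to 4-chlorophenyl. Within the data shown here, no measured pair differs only in this way. Among the measured compounds shown here, compound 1 carries the same chloro group but also a different aryl on the chain, so its gap to compound 2 and to compound 3 cannot be split between the two changes; it shows only that the chloro-bearing compound has the highest number of the three. On that thin basis a modest rise is expected for compound 4, a 1.5-fold higher number from compound 3 to compound 4 (0.18 log units; within the scatter), with wide uncertainty. Compound 4 is estimated at 9500 nM, in the range 3000 nM to 30000 nM.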

Compound 4, concentration for 50% growth inhibition: 1830 nM
Compound 4: the middle estimate sits 5.2-fold (0.72 log units) above what was measured; the whole stated range lies above it.
By their numbers in this assay, from the lowest: compounds 4 and 2 (each within the scatter of the next); then compound 3; then compound 1.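

In this assay, among these compounds, chloro in place of hydrogen on an aromatic carbon, para to a large group, gives a 3.4-fold lower number from compound 3 to compound 4 (0.53 log units; beyond the scatter); this is the first pair to isolate the phenyl to 4-chlorophenyl change, and the step is toward stronger growth inhibition. The 4-chlorophenyl group is therefore not tied to a high number: compound 4 gives 1830 nM, whereas compound 1, which has the same group and a different aryl on the chain, gives 18100 nM. No measurement offered here accounts for the step at this position.

Still open, going by these compounds, is whether the step belongs to chloro in particular or would also appear with bromo, trifluoromethyl or an amine at the same place. Also open, on these data alone, is whether it carries over to the 4-hydroxy-3-methoxyphenyl chain of compound 2.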